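The source may hold more compounds than are shown below. What is called first, only, known or untested is meant among the compounds shown, and "the series" means these compounds.

Measured so far in an assay on membranes from HeLa cells for displacement of a labelled ligand from adenosine receptor A3 (Homo sapiens), read by scintillation counting, with a stated time of 180 min, tested at 1 uM; a lower number here means less inhibition, a higher number more inhibition at the concentration tested (going by the name of the read-out):
compound 1, `CCCOC(=O)C1=C(C)NC(=O)NC1c1ccoc1`, gives 11%;
compound 2, `CC1=C(C(=O)OCc2ccccc2)C(c2ccoc2)NC(=O)N1`, gives 1%;
compound 3, `CCCOC(=O)C1=C(C)NC(=O)NC1c1cccs1`, gives 32%.

Compound 1 stands second highest of the three. a number 10 percentage points lower from compound 1 to compound 2 (within the scatter) came with phenyl in place of ethyl on a saturated chain carbon bound to an oxygen next to a carbonyl group, and a number 21 percentage points higher from compound 1 to compound 3 (beyond the scatter) came with thiophen-2-yl in place of furan-3-yl on a saturated ring carbon.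

Compound 4, `CC1=C(C(=O)CC(C)C)C(c2ccoc2)NC(=O)N1`, is not yet measured. It differs from compound 1 by isobutyl in place of propoxy on a carbonyl carbon. Among the compounds with values here, only the step from compound 1 to compound 2 alters the group on that carbonyl carbon, and it stayed within the scatter; no measured step swaps propoxy for isobutyl, so no direction can be read from the data. For compound 4 in this assay, a number 1 percentage points higher from compound 1 to compound 4 (within the scatter) is expected. Compound 4 is therefore estimated at 12%, with a range from 0% to 32%.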

Compound 4, a percentage reported as inhibition, at one concentration (the size of the read-out at that concentration, not a potency): 18%
Compound 4: middle estimate off by 6 percentage points, on the low side; low and high end bracket the measured number.
By their numbers in this assay, from the lowest: compounds 2, 1 and 4 (each within the scatter of the next, the first and the last beyond it); then compound 3.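

Isobutyl in place of propoxy on a carbonyl carbon came with a number 7 percentage points higher from compound 1 to compound 4 (within the scatter), so this position accepts the swap without a change that can be told from scatter. The swap takes out the oxygen of propoxy, and with it the one hydrogen-bond acceptor counted in that group, yet the inhibition at the concentration tested stays within the usual spread. No measurement at hand explains this result.

On these data alone, whether an amine or a longer chain on this carbonyl carbon would move the number beyond the scatter stays open. Also open, as far as these compounds go, is whether isobutyl would behave the same way with the thiophen-2-yl group of compound 3.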